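The source may report more compounds than this note shows. Statements on the series, on what has been measured and on what is new or still open speak of the compounds shown alone.

Series notes, clearance branch. Compound 2 `Nc1nc(C(F)(F)F)cc2c1[nH]c(=O)n2Cc1ccc(NCCN2CCCC2)nc1` sits at the low end of what has been seen in an in vitro ADME assay on microsomes from liver (Rattus norvegicus) for pharmacokinetics; on this read-out lower numbers stand for slow clearance and higher numbers for fast clearance; for compound 2 the assay returns only a limit, < 8.5 mL.min-1.g-1, and no number (the limit of < 8.5 mL.min-1.g-1 in this assay, at which 1 of the 3 values shown sits). Compound 1 `CN(CCN1CCCCC1)c1ccc(Cn2c(=O)[nH]c3c(N)nc(C(F)(F)F)cc32)cn1` gives 13 mL.min-1.g-1 in this assay. Compound 3 `CN1CCN(c2ccc(Cn3c(=O)[nH]c4c(N)nc(C(F)(F)F)cc43)cn2)CC1` gives 46 mL.min-1.g-1 in this assay.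

The next compound, compound 4 `CN(C)CCN1CCN(c2ccc(Cn3c(=O)[nH]c4c(N)nc(C(F)(F)F)cc43)cn2)CC1`, is not yet measured. Its change from compound 2 is 4-(2-(dimethylamino)ethyl)piperazin-1-yl in place of (2-(pyrrolidin-1-yl)ethyl)amino on an aromatic carbon.

Within the data shown here, two measured steps bear on this. The step of an at least 5.4-fold higher number from compound 2 to compound 3 (0.73 log units; beyond the scatter) puts a 4-methylpiperazin-1-yl group at the same position, and the step of a 3.5-fold higher number from compound 1 to compound 3 (0.55 log units; beyond the scatter) points the same way from a different starting amine. Both rise, and the entering group in compound 4 shares the six-membered non-aromatic ring with 2 hetero atoms of that 4-methylpiperazin-1-yl group, so a rise beyond the scatter is expected for compound 4, of about an at least 3.5-fold higher number from compound 2 to compound 4 (0.54 log units; beyond the scatter). The estimate for compound 4 in this assay is therefore 30 mL.min-1.g-1, with a range from 12 mL.min-1.g-1 to 75 mL.min-1.g-1.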

Compound 4, intrinsic clearance in microsomes: < 8.5 mL.min-1.g-1
Compound 4 was reported as a limit; the forecaster's own chance of this, stated with the estimate: 10%; middle value at least 3.5-fold (0.54 log units) away from the limit.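

At this position, the six-membered ring with 2 hetero atoms does not by itself fix the direction of the read-out in (this assay): 4-(2-(dimethylamino)ethyl)piperazin-1-yl against 4-methylpiperazin-1-yl gives the opposite of the earlier rise (an at least 5.4-fold lower number from compound 3 to compound 4 (0.73 log units; beyond the scatter)), so the group carried on the piperazine matters. The other readable step (an at least 1.5-fold lower number from compound 1 to compound 4 (0.18 log units; that floor lies within the scatter)) sets no order, and the step between the two limits cannot be read. Compound 4 is reported only as a limit: the limit of < 8.5 mL.min-1.g-1 in this assay, at which 2 of the 4 values shown sit.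

From the compounds shown here alone, the size of the fall stays open, with only a limit on that side. Also open, going by these compounds, is whether it follows the dimethylamino group or the chain alone: a piperazine bearing a 2-hydroxyethyl or 2-methoxyethyl group would separate the two.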